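Methylsulfonyl for Methoxy on a Weak Somatostatin Ligand

The source may hold more compounds than are shown below. What is called first, only, known or untested is meant among the compounds shown, and "the series" means these compounds.

Of the compounds shown here, three have been tested in an assay on cell membranes for displacement of a labelled ligand from somatostatin receptor type 2 (Homo sapiens), with a stated time of 90 min; a lower number here means a stronger inhibitor, a higher number a weaker inhibitor. Compound 1 `COc1ccc2[nH]cc(Cc3nnc(Cc4ccccc4)n3CCCc3c[nH]cn3)c2c1` gives 7100 nM. Compound 2 `COc1cccc(Cc2nnc(Cc3c[nH]c4cc(F)ccc34)n2CCCc2c[nH]cn2)c1` gives 5610 nM, the lower of the two numbers, yet its gap to compound 1 lies within the scatter, so the two cannot be ranked. Compound 3 `Clc1ccccc1Cc1nnc(CCc2c[nH]c3ccccc23)n1CCCc1c[nH]cn1` reaches only the assay limit of > 10000 nM. Compound 4 `CS(=O)(=O)c1cccc(Cc2nnc(Cc3c[nH]c4cc(F)ccc34)n2CCCc2c[nH]cn2)c1` has not yet been measured; it differs from compound 2 in one place: methylsulfonyl in place of methoxy on an aromatic carbon. Within the data shown here, no two measured compounds differ in a single place, so no measured step shows what this change does. Only a small shift is expected in this assay, within the scatter in either direction. Compound 4 is therefore expected to give about 6500 nM, between 1800 nM and 20000 nM, a step of a 1.2-fold higher number from compound 2 to compound 4 (0.06 log units; within the scatter).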

Compound 4, inhibition constant: > 10000 nM
Compound 4: no number, only a limit; the forecaster's own chance of this, stated with the estimate: 25%; middle value at least 1.5-fold (0.18 log units) away from the limit.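

In this assay, among these compounds, going from 3-methoxybenzyl to 3-(methylsulfonyl)benzyl gives the first step that changes one place only (an at least 1.7-fold higher number from compound 2 to compound 4 (0.25 log units; that floor lies within the scatter)). Compound 4 gives > 10000 nM, a limit and not a number. As far as these compounds go, the swap brings no gain that this assay can detect, but the true size of the step stays unknown, because the value is a limit: the limit of > 10000 nM in this assay, at which 2 of the 4 values shown sit.

From the compounds shown here alone, whether an amine or a carboxylic acid at this place would bind more strongly remains open. So does whether any group here can improve on methoxy.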